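Aromatic ring versus vinyl on the exocyclic chain carbon

A few compounds are considered here, and "the series" means these few. Any claim that something is new, unique, unknown or untested is made for them only; others in the source may bear on it.

Among the compounds with values here, compound 2 `C=C/C=C1\C=C(C)C2(CC2)C(C)(O)C1=O` holds the only number so far in a functional assay on A549 cells (Homo sapiens) for antiproliferative activity; a lower number here means a stronger inhibitor, a higher number a weaker inhibitor: compound 2 gives 2 nM. Compound 1 `CC1=C/C(=C\c2cccs2)C(=O)C(C)(O)C12CC2` reaches only a limit of the assay, > 10000 nM. Within the data shown here, the single measured step bears directly on the question: an at least 5000-fold lower number from compound 1 to compound 2 (3.69 log units; beyond the scatter). Compound 3 `CC1=C/C(=C\c2ccccc2)C(=O)C(C)(O)C12CC2` carries phenyl in place of vinyl on a double-bonded chain carbon bound to a double-bonded ring carbon, so an aromatic ring returns where compound 1 carried thiophen-2-yl. A step of comparable size back toward the limit of > 10000 nM in this assay, at which 1 of the 2 values shown sits, is expected, a 2000-fold higher number from compound 2 to compound 3 (3.30 log units; beyond the scatter). For compound 3 the estimate is 4000 nM, in the range 300 nM to 20000 nM.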

Compound 3, half-maximal inhibitory concentration: 1500 nM
Beside the measured number, compound 3's estimate is 2.7-fold (0.43 log units) above it, within the range that was stated.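

In this assay, thiophen-2-yl is not alone in falling far behind vinyl on this double-bonded chain carbon: phenyl does too, with a 750-fold higher number from compound 2 to compound 3 (2.88 log units; beyond the scatter). The two aromatic rings also separate from each other, with an at least 6.6-fold lower number from compound 1 to compound 3 (0.82 log units; beyond the scatter). That step has no fixed size, as compound 1 reaches only a limit: the limit of > 10000 nM in this assay, at which 1 of the 3 values shown sits.

From the compounds shown here alone, whether the strength of compound 2 needs the double bond of vinyl or only a small chain stays open. Ethyl or a longer chain such as 1-propenyl at this place would bear on that.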